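From naphthalen-1-yl to 3-fluorophenyl in compound 1

The compounds below may be only part of what the source reports. "The series", "measured", "known", "first", "only" and "open" are said of these compounds alone.

In a functional assay on RS4-11 cells (Homo sapiens) for inhibition, read by CCK-8 assay, with a stated time of 48 h, tested at 20 uM (on this read-out lower numbers stand for less inhibition of growth and higher numbers for more inhibition of growth at the one concentration tested), compound 1 `Cc1ccc(S(=O)(=O)Oc2ccccc2/C=C(\C#N)C(=O)Nc2nnc(Cc3cccc4ccccc34)s2)cc1` gives 73%. Compound 2 `N#C/C(=C\c1ccccc1OS(=O)(=O)c1ccccc1[N+](=O)[O-])C(=O)Nc1nnc(Cc2cccc3ccccc23)s1` gives 66%, and compound 3 `N#C/C(=C\c1ccccc1OS(=O)(=O)c1ccc(F)cc1)C(=O)Nc1nnc(Cc2cccc3ccccc23)s1` gives 68%, so all three stand level within the scatter. Changing the group on the sulfonyl sulfur gave only small steps: a number 7 percentage points lower from compound 1 to compound 2 (within the scatter), a number 5 percentage points lower from compound 1 to compound 3 (within the scatter) and a number 2 percentage points higher from compound 2 to compound 3 (within the scatter). Compound 4 `Cc1ccc(S(=O)(=O)Oc2ccccc2/C=C(\C#N)C(=O)Nc2nnc(Cc3cccc(F)c3)s2)cc1` changes a different place: 3-fluorophenyl in place of naphthalen-1-yl on a saturated chain carbon bound to an aromatic carbon. There, 3-fluorophenyl stands in place of naphthalen-1-yl on a saturated chain carbon bound to an aromatic carbon. For the measured compounds named here, no measured step touches this place, so the direction is uncertain and the range must be wide. The expected change is a number 13 percentage points lower from compound 1 to compound 4 (beyond the scatter), a cautious guess at a modest loss. For compound 4 the estimated value is 60%, with an expected range of 35% to 80%.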

Compound 4, percent growth inhibition at one concentration: 56%
For compound 4 the middle estimate is 4 percentage points above the measured one; measured number inside the range.
By their numbers in this assay, from the lowest: compounds 4, 2, 3 and 1 (each within the scatter of the next, the first and the last beyond it).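

The earlier steps shown here all changed the group on the sulfonyl sulfur and stayed within the scatter, whereas in this assay this change on a saturated chain carbon bound to an aromatic carbon gives a number 17 percentage points lower from compound 1 to compound 4 (beyond the scatter) and so moves the number beyond it. This place therefore responds where the sulfonyl changes shown did not, as two aromatic rings give way to one bearing fluorine. No evidence here explains the drop.

The compounds shown cannot separate losing the second ring from adding fluorine. An unsubstituted benzyl group, or an amine at this place, would help tell the two apart.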